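Lengthening the chain from compound 2 to compound 3

The source may report more compounds than this note shows. Statements on the series, on what has been measured and on what is new or still open speak of the compounds shown alone.

Measured compounds (a functional assay on HCT-116 cells (Homo sapiens) for antiproliferative activity, read by MTT assay, with a stated time of 48 h; a higher number here means a weaker inhibitor of growth, a lower number a stronger inhibitor of growth)
compound 1 `Cc1ccc(-c2cnc(N(Cc3ccc(C(=O)NO)cc3)CC(C)C)s2)cc1` (5900 nM)
compound 2 `CCN(Cc1ccc(C(=O)NO)cc1)c1ncc(-c2ccc(C)cc2)s1` (6870 nM)

Compound 2 lies within the scatter of compound 1, so the two cannot be ranked. Compound 3 `CCCCCCCCN(Cc1ccc(C(=O)NO)cc1)c1ncc(-c2ccc(C)cc2)s1` has hexyl in place of hydrogen on a saturated chain carbon, two bonds along the chain from a nitrogen on an aromatic ring, which reads as ethyl to octyl. Within the data shown here, only one measured step bears on this: a 1.2-fold higher number from compound 1 to compound 2 (0.07 log units; within the scatter), with methyl in place of isopropyl. Among the measured compounds shown here, no measured compound carries a chain this long, so the guidance is weak, and no clear shift is expected in this assay. The expected change is small, a 1.5-fold lower number from compound 2 to compound 3 (0.18 log units; within the scatter), with a slightly lower number favoured. Compound 3 is estimated at 4500 nM (range 1500 nM to 12000 nM).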

Compound 3, concentration for 50% growth inhibition: 6500 nM
Beside the measured number, compound 3's estimate is 1.4-fold (0.16 log units) below it; the range from low to high includes it.
By their numbers in this assay, from the lowest: compounds 1, 3 and 2 (each within the scatter of the next).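

Within this assay, hexyl in place of hydrogen on a saturated chain carbon, two bonds along the chain from a nitrogen on an aromatic ring, gives a 1.1-fold lower number from compound 2 to compound 3 (0.02 log units; within the scatter), and heptyl in place of isopropyl gives a 1.1-fold higher number from compound 1 to compound 3 (0.04 log units; within the scatter). This position therefore accepts the much longer octyl chain with no readable shift in number, which the earlier, shorter chains could not show. Nothing available explains this flat result. As far as these compounds go, whether a chain longer than octyl, or one ending in an amine or a carboxylic acid, would move the number remains open.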